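This account rests on a few compounds, and the source may have more. Where it says the series, first, only, none or still open, it means among the compounds named here.

The compounds here share one core. Compound 1 `CN(C)CCCOc1ccc(CN2CC[C@H](NC(=O)c3cc(Cl)cc(Cl)c3)C2)cc1` carries a 3,5-dichlorophenyl on its carbonyl carbon, compound 2 `COc1ccc(C(=O)N[C@H]2CCN(Cc3ccc(OCCCN(C)C)cc3)C2)cc1OC` a 3,4-dimethoxyphenyl, and compound 3 `CN(C)CCCOc1ccc(CN2CC[C@H](NC(=O)c3ccc(C(F)(F)F)cc3)C2)cc1` a 4-(trifluoromethyl)phenyl. In an assay on HEK293 cells for binding affinity to Urotensin-2 receptor (Homo sapiens), read by radioligand binding (a lower number here means a stronger inhibitor, a higher number a weaker inhibitor), compound 1 gives 2000 nM. For compound 2 the assay reports only a limit, < 10000 nM. For compound 3 likewise only a limit is reported, < 10000 nM. Two of the three values thus sit at the limit of < 10000 nM in this assay, at which 2 of the 3 values shown sit, and the steps a step that the limit leaves unreadable from compound 1 to compound 2, a step that the limit leaves unreadable from compound 1 to compound 3 and a step that the two limits leave unreadable from compound 2 to compound 3 cannot be sized. Compound 4 `CN(C)CCCOc1ccc(CN2CC[C@H](NC(=O)c3ccccc3)C2)cc1` has not yet been measured; it differs from compound 2 by phenyl in place of 3,4-dimethoxyphenyl on a carbonyl carbon. Among the compounds with values here, none of the measured steps gives a readable size for a change at this carbonyl carbon, so compound 2 offers only a ceiling to build on. Compound 1 does give a readable 2000 nM in this assay. On that basis compound 4 is expected to land near 3500 nM, with a likely range from 800 nM to 15000 nM. As far as these compounds go, the step from compound 2 to compound 4 that this estimate means is expected to be a step that the limit leaves unreadable from compound 2 to compound 4, though its true size will remain open until the measurement is in hand.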

Compound 4, inhibition constant: 2510 nM
Compound 4: the middle estimate sits 1.4-fold (0.14 log units) above what was measured; low and high end bracket the measured number.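

In this assay the shared core now has a second readable value at this carbonyl carbon, and the change from 3,5-dichlorophenyl to phenyl appears as a 1.3-fold higher number from compound 1 to compound 4 (0.10 log units; within the scatter). Phenyl and 3,5-dichlorophenyl cannot be told apart here, so the two chlorine atoms are not required for a reading at this level. The steps to compound 4 from compound 2 and from compound 3 cannot be read, because compound 2 and compound 3 each carry only a limit: the limit of < 10000 nM in this assay, at which 2 of the 4 values shown sit.

As far as these compounds go, how far compound 2 and compound 3 really lie from compound 4 remains open. Also open, from the compounds shown here alone, is whether an aromatic ring is needed on this carbonyl carbon at all, and how a cyclohexyl group or a pyridine ring would read there.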